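This account rests on a few compounds, and the source may have more. Where it says the series, first, only, none or still open, it means among the compounds named here.

Measured compounds:
Compound 1 `CCC(c1ccc(-c2cscc2C)cc1)n1ccnc1` gives 84% in an assay for inhibition of steroid 17-alpha-hydroxylase/17,20 lyase (Homo sapiens), using NADPH, tested at 2 uM; a higher number here means a stronger effect of the compound at the concentration tested, a lower number a weaker effect.
Compound 2 `Cc1cscc1-c1ccc(Cn2ccnc2)cc1` gives 27%.
Compound 3 `CCC(c1cc(-c2ccc(F)c(F)c2)cs1)n1ccnc1` gives 68%.

The first two compounds share one core and differ in a single place: hydrogen in place of ethyl on a saturated chain carbon bound to an aromatic carbon and an aromatic nitrogen. That single change made a large difference in the read-out, a number 57 percentage points lower from compound 1 to compound 2 (beyond the scatter). Compound 3 sits on a different core; the difference between the two cores is not broken down here. Compound 3 stands second highest of the three numbers, and the gaps to the other two lie beyond the usual scatter.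

Compound 4 `Fc1ccc(-c2csc(Cn3ccnc3)c2)cc1F` has not yet been measured. It relates to compound 3 by hydrogen in place of ethyl on a saturated chain carbon bound to an aromatic carbon and an aromatic nitrogen, which is the same change, at the same place, as the one seen between the first two compounds, so this change occurs twice among these compounds. Among the compounds with values here, the expectation for compound 4 rests on the only other instance of the change, a number 57 percentage points lower from compound 1 to compound 2 (beyond the scatter). A step of similar size is therefore expected here, a number 50 percentage points lower from compound 3 to compound 4 (beyond the scatter), while noting that a single earlier example gives a weak basis. Compound 4 is estimated to give 18% in this assay, expected to lie between 5% and 40%.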

Compound 4, a percentage reported as inhibition, at one concentration (the size of the read-out at that concentration, not a potency): 25%
The estimate for compound 4 lay 7 percentage points below the measured number, and the stated range covers the measured number.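

Replacing ethyl with hydrogen again cut the read-out in this assay, with a number 43 percentage points lower from compound 3 to compound 4 (beyond the scatter). Set beside the earlier example, the two steps agree on two different cores: the same change on two cores in this assay, a number 57 percentage points lower (beyond the scatter) from compound 1 to compound 2 and a number 43 percentage points lower (beyond the scatter) from compound 3 to compound 4, 14 percentage points apart, within the scatter of two such steps So in these four compounds, the loss on removing ethyl carried over from one core to the other in both direction and approximate size, but two examples cannot show that it would hold on further cores, and a percentage at one concentration is not a potency, nor does it explain why the change matters.

The carbon bearing the imidazole-linked substituent is shown here with only ethyl or hydrogen, so it remains open how a smaller methyl, a longer propyl chain or a hydroxyl group would behave at that place. Going by these compounds, it is also open whether any such group would match or exceed ethyl on either core.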